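The compounds below may be only part of what the source reports. "The series", "measured", "known", "first", "only" and "open" are said of these compounds alone.

Compound 3 `CC(C)NC(=O)NS(=O)(=O)c1cc(C#N)ccc1Oc1ccc(Br)cc1` gives 9470 nM in a functional assay on HEK293 cells for antagonist activity at thromboxane A2 receptor (Homo sapiens), read by fluorescence and calcium flux (a higher number here means a weaker inhibitor, a lower number a stronger inhibitor), the highest of the three numbers; compound 2 `CC(C)NC(=O)NS(=O)(=O)c1cc(C#N)ccc1Oc1ccc(Cl)cc1` gives 9460 nM, and the step of a 1.0-fold higher number from compound 2 to compound 3 (0.00 log units; within the scatter) lies within the scatter, whereas compound 1 `Cc1cccc(Oc2ccc(C#N)cc2S(=O)(=O)NC(=O)NC(C)C)c1` gives 2380 nM, with the step of a 4.0-fold higher number from compound 1 to compound 3 (0.60 log units; beyond the scatter) lying beyond it. Compound 4 `Cc1cccc(Nc2ccc(C#N)cc2S(=O)(=O)NC(=O)NC(C)C)c1` differs from compound 3 by (3-methylphenyl)amino in place of 4-bromophenoxy on an aromatic carbon, placed on an aromatic carbon ortho to a large group and para to a cyano group. The step of a 4.0-fold higher number from compound 1 to compound 3 (0.60 log units; beyond the scatter) bears on this: it exchanges the same two aromatic groups across an oxygen link. Within the data shown here, no measured step covers the change from an oxygen to a nitrogen link, so the expectation rests on compound 1 alone. The expected step is therefore a 3.8-fold lower number from compound 3 to compound 4 (0.58 log units; beyond the scatter). Compound 4 is estimated at 2500 nM, within 800 nM to 8000 nM.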

Compound 4, half-maximal inhibitory concentration: 9500 nM
Beside the measured number, compound 4's estimate is 3.8-fold (0.58 log units) below it; measured number above the stated range.
By their numbers in this assay, from the lowest: compound 1; then compounds 2, 3 and 4 (each within the scatter of the next).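

Among these compounds, exchanging the oxygen link for a nitrogen link while keeping the 3-methylphenyl group gives a 4.0-fold higher number from compound 1 to compound 4 (0.60 log units; beyond the scatter) in this assay and so shows that the link itself counts at this position, which the earlier compounds, all linked through oxygen, could not show. The steps of a 1.0-fold higher number from compound 3 to compound 4 (0.00 log units; within the scatter) and a 1.0-fold higher number from compound 2 to compound 4 (0.00 log units; within the scatter) place the nitrogen-linked compound with the 4-chlorophenoxy and 4-bromophenoxy compounds, so the advantage that 3-methylphenyl showed on oxygen does not appear with the nitrogen link. Nothing measured here gives a reason for this.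

Still open, from the compounds shown here alone, is whether a 4-chlorophenyl or 4-bromophenyl group on the nitrogen link would give a number like that of compound 4. Also open, going by these compounds, is whether a sulfur or methylene link would behave like oxygen or like nitrogen.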